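Adding a Methoxy Group to Compound 3

A few compounds are considered here, and "the series" means these few. Any claim that something is new, unique, unknown or untested is made for them only; others in the source may bear on it.

Compound 1, `[O-]/[N+](=C\c1cn(-c2ccccc2)nn1)c1ccccc1`: in a functional assay on PC-3 cells (Homo sapiens) for inhibition, read by MTT assay, with a stated time of 24 h (a lower number here means a stronger inhibitor, a higher number a weaker inhibitor), compound 1 reports > 100000 nM, which is a limit of the assay rather than a number.
Compound 2, `[O-]/[N+](=C\c1cn(-c2ccc(F)cc2)nn1)Cc1ccccc1`: compound 2 reports > 100000 nM, also a limit.
Compound 3, `CC(C)(C)/[N+]([O-])=C/c1cn(-c2ccccc2)nn1`: compound 3 gives 15400 nM.

Going by the values given here, compound 3 therefore holds the only true number; the other two sit at the limit of > 100000 nM in this assay, at which 2 of the 3 values shown sit. Among the compounds with values here, the single measured step, an at least 6.4-fold lower number from compound 1 to compound 3 (0.81 log units; beyond the scatter), concerns the group on the double-bonded nitrogen and says nothing about the phenyl ring. Compound 4, `COc1ccc(-n2cc(/C=[N+](\[O-])C(C)(C)C)nn2)cc1`, differs from compound 3 by methoxy in place of hydrogen on an aromatic carbon. Within the data shown here, no measured pair isolates this change; compound 2 carries a ring substituent but also a different group on the nitrogen, so its limit cannot be read as a step. In this assay the expected step is accordingly small, a 1.3-fold lower number from compound 3 to compound 4 (0.11 log units; within the scatter), within the scatter. Compound 4 is estimated at 12000 nM, between 5000 nM and 40000 nM.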

Compound 4, half-maximal inhibitory concentration: 23800 nM
Compound 4: middle estimate off by 2.0-fold (0.30 log units), on the low side; the measured number falls inside the stated range.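

Going by these compounds alone, compound 4 gives the first readable step at this place on the aromatic ring: methoxy in place of hydrogen yields a 1.5-fold higher number from compound 3 to compound 4 (0.19 log units; within the scatter) in this assay. The earlier step spoke only of the group on the double-bonded nitrogen, whereas this one shows that a methoxy group here leaves the number within the usual scatter. The compounds shown offer no explanation for this result.

On these data alone, whether an amine, a carboxylic acid or a longer chain at this place would move the number beyond the scatter remains open. So does whether methoxy would give the same small step with phenyl on the nitrogen instead of tert-butyl.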